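Dichlorophenyl in place of hydroxyphenyl on the shared core

The compounds below may be only part of what the source reports. "The series", "measured", "known", "first", "only" and "open" are said of these compounds alone.

Measured compounds:
compound 1 `COC(=O)C1=C(C)N=C(C)/C(=C(\O)OC)C1c1cccc(O)c1`: 1000 nM
compound 2 `COC(=O)C1=C(C)N=C(C)/C(=C(\O)OC)C1c1cccc([N+](C)(C)C)c1`: 50100 nM

In a functional assay (muscle tissue) with Cavia porcellus as the target (on this read-out lower numbers stand for an effect already at smaller amounts and higher numbers for an effect only at larger amounts of compound), compound 1 gives 1000 nM, the lower of the two numbers; compound 2 gives 50100 nM. For the measured compounds named here, the one measured step, a 50-fold higher number from compound 1 to compound 2 (1.70 log units; beyond the scatter), replaced the oxygen atom on the aromatic carbon with a group of 4 heavy atoms.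

Compound 3 `COC(=O)C1=C(C)N=C(C)/C(=C(\O)OC)C1c1ccc(Cl)cc1Cl` has not yet been measured. Compared with compound 1 the change is 2,4-dichlorophenyl in place of 3-hydroxyphenyl on a saturated ring carbon. Going by the values given here, the step from compound 1 to compound 2 bears on this only partly: it shows that exchanging the group on the aromatic ring can move the number a great deal, but the group entering in compound 3 is of a different kind, with two chlorine atoms and no donor or acceptor, and no measured pair shows such an exchange. The expectation for compound 3 is therefore wide; a step of a 1.7-fold lower number from compound 1 to compound 3 (0.22 log units; within the scatter) is expected, which is within the scatter, and compound 3 is estimated at 600 nM, with a range from 60 nM to 6000 nM.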

Compound 3, half-maximal effective concentration: 640 nM
The estimate for compound 3 lay 1.1-fold (0.03 log units) below the measured number, within the range that was stated.
By their numbers in this assay, from the lowest: compounds 3 and 1 (each within the scatter of the next); then compound 2.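

In this assay, putting 2,4-dichlorophenyl in place of 3-hydroxyphenyl on the saturated ring carbon gives a 1.6-fold lower number from compound 1 to compound 3 (0.19 log units; within the scatter) and so leaves the two compounds indistinguishable on this read-out. For the compounds shown here, the earlier pair showed only that a change on the aromatic ring can move the number a long way, whereas this pair shows that a far-reaching exchange at this position need not do so: the entering group has 0 hydrogen-bond donors and 0 hydrogen-bond acceptors and carries two chlorine atoms, yet compound 3 stays within the scatter of compound 1, so the hydroxyl of compound 1 is not required for a number of this size. No measurement shown here offers an explanation for this outcome.

The pair cannot tell what each chlorine atom contributes, since both enter together with the loss of the hydroxyl, and a phenyl ring with a single chlorine would be needed to separate them. From the compounds shown here alone, how a neutral amine or a carboxylic acid on the phenyl ring would read in this assay also remains open, as does any change to the methoxycarbonyl or methyl groups on the shared core.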